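Two aryl groups exchanged on a shared thiazole-free core

A few compounds are considered here, and "the series" means these few. Any claim that something is new, unique, unknown or untested is made for them only; others in the source may bear on it.

Three compounds carrying a carboxymethyl group on a common five-membered core have been measured in an in vitro functional assay on HEK285-7 cells for antagonist activity at prostaglandin D2 receptor 2 (Homo sapiens), read by BRET and beta-arrestin recruitment; on this read-out lower numbers stand for stronger inhibition and higher numbers for weaker inhibition. Compound 1 `O=C(O)Cc1sc(COc2ccc(Cl)cc2)nc1-c1ccc(Cl)cc1` gives 370 nM, and compound 2 `O=C(O)Cc1sc(C(c2ccccc2)c2ccccc2)nc1-c1ccccc1` gives 370 nM in this assay. Compound 3 `N#Cc1cc(-c2nc(C(c3ccc(F)cc3)c3ccc(F)cc3)sc2CC(=O)O)ccc1F` gives 520 nM, the highest of the three numbers, yet its gaps to compound 1 and to compound 2 are both within the usual scatter, so the three compounds cannot be ranked against one another.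

Compound 4 `O=C(O)Cc1sc(C(c2ccc(F)cc2)c2ccc(F)cc2)nc1-c1ccnc(N2CCC2)c1` has not yet been measured. It differs from compound 3 in one place: 2-(azetidin-1-yl)pyridin-4-yl in place of 3-cyano-4-fluorophenyl on an aromatic carbon. No step between measured compounds covers this kind of change, so there is no shown step to lean on. Across the three measured compounds the large group and the aromatic substituent vary considerably while the numbers stay close together, which suggests that compound 4 may also fall near them.

The account therefore expects no step beyond the scatter from compound 3 to compound 4, with a 1.0-fold lower number from compound 3 to compound 4 (0.02 log units; within the scatter) as the estimated change in this assay. For compound 4 the estimate in this assay is 500 nM, with a range from 150 nM to 1700 nM.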

Compound 4, half-maximal inhibitory concentration: > 100000 nM
Compound 4 ended at the assay's limit; the forecaster's own chance of this, stated with the estimate: 5%; middle value at least 200-fold (2.30 log units) away from the limit.
By their numbers in this assay, from the lowest: compounds 1, 2 and 3 (each within the scatter of the next). At a limit, above all of these: compound 4.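

In this assay, the aromatic carbon next to the ring nitrogen and next to the ring atom that bears a carboxymethyl group proves sensitive to what it carries: 2-(azetidin-1-yl)pyridin-4-yl in place of 3-cyano-4-fluorophenyl gives an at least 190-fold higher number from compound 3 to compound 4 (2.28 log units; beyond the scatter), with everything else in the molecule unchanged. For the compounds shown here, compounds 1, 2 and 3 differ from one another in more than one place and offered no step at this position, so this is the first change read there on its own, and it shows that this position does not tolerate every aromatic group. Compound 4 gives > 100000 nM, which is a limit of the assay and not a number: the limit of > 100000 nM in this assay, at which 1 of the 4 values shown sits.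

The compounds shown do not tell whether the higher number goes with the nitrogen of the pyridine ring, with the azetidine ring, or only with the two together, as this change brings in both at once. Nor do they tell how a plain pyridinyl group, or a phenyl group carrying a dimethylamino group, would read at this position.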